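Fluoro in Place of Cyano on the Fused Ring

A few compounds are considered here, and "the series" means these few. Any claim that something is new, unique, unknown or untested is made for them only; others in the source may bear on it.

Compound 3 `Cc1ncccc1-c1cnc(NCc2c(F)cc(C#N)c3c2CCO3)n2cnnc12` gives 15000 nM in an assay on isolated protein for binding affinity to Polycomb protein EED (Homo sapiens), read by surface plasmon resonance (a higher number here means weaker binding, a lower number tighter binding), the highest of the two numbers at hand; its nearest neighbour, compound 1 `Cc1ncccc1-c1cnc(NCc2c(F)cc(Cl)c3c2CCO3)n2cnnc12`, gives 2400 nM in this assay. Compound 2 `Cc1ncccc1-c1cnc(NCc2c(F)cc(O)c3c2CCO3)n2cnnc12` gives "not determined" (no result reported) in this assay. Among the compounds with values here, the only measured step, from compound 1 to compound 3, is a 6.3-fold higher number from compound 1 to compound 3 (0.80 log units; beyond the scatter), a cyano replacing a chloro on the same aromatic carbon. Compound 4 `Cc1ncccc1-c1cnc(NCc2c(F)cc(F)c3c2CCO3)n2cnnc12` differs from compound 3 by fluoro in place of cyano on an aromatic carbon. Because compound 1 gave 2400 nM with a halogen at this carbon, a halogen again here is expected to lower the number by a modest amount. Compound 4 is therefore estimated at 4000 nM, with a range of 1500 nM to 12000 nM in this assay. The expected step is a 3.8-fold lower number from compound 3 to compound 4 (0.57 log units; beyond the scatter).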

Compound 4, dissociation constant: 1200 nM
Estimate against measurement, compound 4: 3.3-fold (0.52 log units) above; measured number below the stated range.
By their numbers in this assay, from the lowest: compounds 4 and 1 (each within the scatter of the next); then compound 3.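

In this assay the change to fluoro gives a 13-fold lower number from compound 3 to compound 4 (1.10 log units; beyond the scatter) and so reverses the loss seen with the nitrile at this aromatic carbon. The two halogens do not separate, with a 2.0-fold lower number from compound 1 to compound 4 (0.30 log units; within the scatter) as the step between them, and compound 3 alone stands apart as the weakest binder of the three numbers. No measurement shown here explains why the nitrile differs from chloro and fluoro. On these data alone, whether a methoxy group, an amine or plain hydrogen at this carbon would read like the halogens or like the nitrile remains open.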